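This account rests on a few compounds, and the source may have more. Where it says the series, first, only, none or still open, it means among the compounds named here.

The study compares three measured compounds in a functional assay on DU-145 cells (Homo sapiens) for antiproliferative activity, read by trypan blue exclusion; on this read-out lower numbers stand for stronger inhibition and higher numbers for weaker inhibition. Compound 1, with the structure `COc1cc(OC)c(/C=C/S(=O)(=O)Cc2ccc(OC)c(OC)c2OC)c(OC)c1`, gives 12500 nM in this assay. Compound 2, with the structure `COc1cc(OC)c(/C=C/S(=O)(=O)Cc2ccc([N+](=O)[O-])cc2)c(OC)c1`, gives 15000 nM. Compound 3, built as `COc1ccc(CS(=O)(=O)/C=C/c2ccc(F)cc2)cc1`, gives 1250 nM. On these numbers compound 3 stands lowest of the three, and its distance to each of the others lies beyond the scatter of repeated measurements, so among the measured compounds it is the most potent; compound 1 is its nearest neighbour and compound 2 its furthest.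

The next compound, compound 4, has the structure `COc1ccc(CS(=O)(=O)/C=C/c2ccc(N)cc2)cc1`. It differs from compound 3 in one place: amino in place of fluoro on an aromatic carbon. Going by the values given here, no pair of measured compounds shows what this exchange does in this assay, and neither compound 1 nor compound 2 shares the core of compound 3, so they give no guidance on it. The account therefore rests on compound 3 alone. The expectation is a small step, if any, from compound 3 to compound 4, a 1.3-fold lower number from compound 3 to compound 4 (0.10 log units; within the scatter), and not one clearly beyond the scatter in either direction. For compound 4 the estimated value in this assay is 1000 nM, within a range from 300 nM to 3500 nM.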

Compound 4, half-maximal inhibitory concentration: > 20000 nM
Compound 4 ended at the assay's limit; the forecaster's own chance of this, stated with the estimate: 5%; middle value at least 20-fold (1.30 log units) from the limit.
By their numbers in this assay, from the lowest: compound 3; then compounds 1 and 2 (each within the scatter of the next). At a limit, above all of these: compound 4.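

In this assay, going by these compounds alone, the exchange of 4-fluorophenyl for 4-aminophenyl gives an at least 16-fold higher number from compound 3 to compound 4 (1.20 log units; beyond the scatter), the first reading of any single change. Going by these compounds, compound 4 gives > 20000 nM, which is a limit of the assay and not a number, so the step fixes only the smallest size the change can have, and how far it really reaches stays unknown: the limit of > 20000 nM in this assay, at which 1 of the 4 values shown sits. What the pair does show is that this position, on the aromatic ring and para to a large group, is not indifferent to a small exchange, since one heavy atom replaces one heavy atom here, with one hydrogen-bond donor and one hydrogen-bond acceptor coming in, and the read-out moves beyond the scatter.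

A single pair cannot tell whether the step follows from the fluoro group leaving or from the amino group entering. The compounds shown also leave open how a hydroxyl, a chlorine, a methoxy group, an acetamide or a carboxylic acid at this same position would read on the core of compound 3.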